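Swapping a trifluoromethyl for a nitro on the anilino ring

This account rests on a few compounds, and the source may have more. Where it says the series, first, only, none or still open, it means among the compounds named here.

Of the compounds shown here, three sharing one core have been tested in a functional assay on MGC-803 cells (Homo sapiens) for cytotoxicity, read by MTT assay, with a stated time of 72 h; a higher number here means a weaker inhibitor, a lower number a stronger inhibitor. Compound 1 `CCCCCCNc1nc(SCc2ccc(C(F)(F)F)cc2)nc2ccccc12` gives 13100 nM. Compound 3 `FC(F)(F)c1ccc(CSc2nc(Nc3cccc(C(F)(F)F)c3)c3ccccc3n2)cc1` gives 15100 nM, and a 1.2-fold higher number from compound 1 to compound 3 (0.06 log units; within the scatter). Compound 2 `CCOc1ccccc1Nc1nc(SCc2ccc(C(F)(F)F)cc2)nc2ccccc12` reaches only the limit of this assay, > 50000 nM, which is a limit rather than a number. Accordingly an at least 3.3-fold lower number from compound 2 to compound 3 (0.51 log units; beyond the scatter). Among the two actual numbers, compound 3 sits beside compound 1, and nothing separates them beyond the scatter.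

Compound 4 `O=[N+]([O-])c1cccc(Nc2nc(SCc3ccc(C(F)(F)F)cc3)nc3ccccc23)c1` differs from compound 3 in one place: nitro in place of trifluoromethyl on an aromatic carbon. The measured steps all concern what hangs on the ring nitrogen, not a substituent on the aromatic carbon, so they bear on this change only loosely; they show that a 1.2-fold higher number from compound 1 to compound 3 (0.06 log units; within the scatter), while an at least 3.3-fold lower number from compound 2 to compound 3 (0.51 log units; beyond the scatter). Among the compounds with values here, with no step of the same kind available, a change beyond the scatter is not expected here, and a 1.0-fold lower number from compound 3 to compound 4 (0.00 log units; within the scatter) is the estimated outcome. Compound 4 is therefore expected to give about 15000 nM in this assay, between 5000 nM and 45000 nM.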

Compound 4, half-maximal inhibitory concentration: > 50000 nM
Compound 4: no number, only a limit; the forecaster's own chance of this, stated with the estimate: 15%; at least 3.3-fold (0.52 log units) between middle value and limit.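

In this assay compound 4 gives > 50000 nM, which is a limit of the assay and not a number. Even so, the single exchange of trifluoromethyl for nitro on this aromatic carbon can be read, and it gives an at least 3.3-fold higher number from compound 3 to compound 4 (0.51 log units; beyond the scatter), so these two groups are not interchangeable at this place. The 3-nitrophenyl group also stands apart from hexyl on the same nitrogen, with an at least 3.8-fold higher number from compound 1 to compound 4 (0.58 log units; beyond the scatter).

As far as these compounds go, the step between compound 2 and compound 4 cannot be read, and how far compound 4 lies past the limit stays open: the limit of > 50000 nM in this assay, at which 2 of the 4 values shown sit. Whether nitro is unusual here or trifluoromethyl is the group that stands out remains unsettled, and a nitrile, a methyl or an amine on the same aromatic carbon would help to separate these two readings.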